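Moving the ring nitrogen: compound 1 to compound 4

A few compounds are considered here, and "the series" means these few. Any claim that something is new, unique, unknown or untested is made for them only; others in the source may bear on it.

Compound 1, with the structure `COc1ccccc1S(=O)(=O)/C=C/c1ccccn1`, was tested in an ADME assay on BV-2 cells (Mus musculus) for cytotoxicity, with a stated time of 24 h, tested at 50 uM (on this read-out higher numbers stand for a weaker effect at the one concentration tested and lower numbers for a stronger effect), where it gives 100%. Compound 3, with the structure `COc1ccccc1S(=O)(=O)/C=C/c1ncccc1Cl`, gives 100%, so the two stand level and together at the top of the three numbers. Compound 2, with the structure `COc1ccccc1S(=O)(=O)/C=C/c1cccc(Cl)n1`, gives 80.5%, the lowest of the three.

The measured steps both add a chloro group: a number 19.5 percentage points lower from compound 1 to compound 2 (beyond the scatter) and no change at the digits printed from compound 1 to compound 3 (within the scatter). Compound 4, with the structure `COc1ccccc1S(=O)(=O)/C=C/c1cccnc1`, differs from compound 1 in another way: pyridin-3-yl in place of pyridin-2-yl on a double-bonded chain carbon bound to a double-bonded chain carbon. Neither measured step involves this kind of change, so they bear on it only loosely; they show that altering the group on the chain end moves this read-out little or modestly, and never upward. Compound 4 is therefore expected to sit close to compound 1, with any step a number 5 percentage points lower from compound 1 to compound 4 (within the scatter) staying within the scatter or at most a modest drop. The estimate for compound 4 is 95%, in the range 75% to 100%.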

Compound 4, a percentage reported as activity, at one concentration (the size of the read-out at that concentration, not a potency): 92%
Beside the measured number, compound 4's estimate is 3 percentage points above it, and the stated range covers the measured number.
By their numbers in this assay, from the lowest: compound 2; then compounds 4, 1 and 3 (each within the scatter of the next).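

In this assay, swapping pyridin-2-yl for pyridin-3-yl on the double-bonded chain carbon gives a number 8 percentage points lower from compound 1 to compound 4 (within the scatter). This is the first step shown that keeps the same atoms and only changes how the ring is joined to the chain, and the change stays within the scatter. So, for these two compounds, the way the pyridine ring is joined does not shift this read-out measurably, and nothing available explains why the two read alike.

Still open, as far as these compounds go, is how pyridin-4-yl or a plain phenyl ring would read at this place on the chain. From the compounds shown here alone, it is also open whether a chloro group on the pyridin-3-yl ring of compound 4 would lower the number, as in a number 19.5 percentage points lower from compound 1 to compound 2 (beyond the scatter), or leave it unchanged, as in no change at the digits printed from compound 1 to compound 3 (within the scatter).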